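The source may report more compounds than this note shows. Statements on the series, on what has been measured and on what is new or still open speak of the compounds shown alone.

Working notes on the series. Compound 1 `CCc1ccc2[nH]c(=O)c(CN(CCCO)Cc3ccc(C(C)(C)C)cc3)cc2c1` and compound 2 `Cc1ccc2[nH]c(=O)c(CN(Cc3ccc(C(C)(C)C)cc3)[C@H](CO)c3ccccc3)cc2c1` share the same core and the same tert-butylbenzyl arm on the amine, and differ at the other arm and in the alkyl group on the core. Both have been run in a toxicity assay on MDCK cells (Canis lupus familiaris) for cytotoxicity, read by crystal violet staining, with a stated time of 48 h; on this read-out lower numbers stand for higher toxicity in this test and higher numbers for lower toxicity in this test. In this assay compound 1 sits at a limit, > 10000 nM, not a measured number. In this assay compound 2 likewise reaches only the limit of > 10000 nM. Where compound 2 stands is therefore set by the limit of > 10000 nM in this assay, at which 2 of the 2 values shown sit, and nothing more: no number separates it from compound 1, and no step between measured compounds is available.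

Compound 3 `CCc1ccc2[nH]c(=O)c(CN(Cc3ccc(C(C)(C)C)cc3)[C@H](CO)c3ccccc3)cc2c1` is the next member, still to be measured in this assay. Against compound 2 the change is methyl in place of hydrogen on a saturated chain carbon bound to an aromatic carbon. On the evidence in hand, compound 1 carrying the ethyl group already sits at the same limit, so no shift beyond the usual scatter is expected for the step that the limit leaves unreadable from compound 2 to compound 3. For compound 3 in this assay the expected value is 15000 nM, with a range from 7000 nM to 40000 nM, most likely reported again as a limit rather than a number.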

Compound 3, half-maximal cytotoxic concentration: > 10000 nM
Compound 3 was reported as a limit; the forecaster's own chance of this, stated with the estimate: 85%; the middle value lies beyond the limit too.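

In this assay compound 3 gives > 10000 nM, a limit and not a number. Within the data shown here, no step from compound 1 or compound 2 to compound 3 can be read: the limit of > 10000 nM in this assay, at which 3 of the 3 values shown sit. The compounds shown leave open whether the ethyl group or either amine arm changes the half-maximal cytotoxic concentration at all.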